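Two small changes in a weakly active series

A few compounds are considered here, and "the series" means these few. Any claim that something is new, unique, unknown or untested is made for them only; others in the source may bear on it.

Compound 1 `COc1cccc(Nc2nc(Oc3cccc(NC(=O)C=C(C)C)c3)c3sccc3n2)c1`: 27700 nM
Compound 2 `COc1cccc(Nc2nc(Oc3cccc(NC(=O)/C=C/C(C)C)c3)c3sccc3n2)c1`: 37100 nM
Compound 3 `COc1ccc(Nc2nc(Oc3cccc(NC(=O)C=C(C)C)c3)c3sccc3n2)cn1`: 40100 nM

All three numbers come from a functional assay on A549 cells (Homo sapiens) for inhibition, read by MTT assay, with a stated time of 72 h; on this read-out lower numbers stand for stronger inhibition and higher numbers for weaker inhibition. Compound 2 is compound 1 with the change (3-methylbut-1-en-1-yl in place of 2-methylprop-1-en-1-yl on a carbonyl carbon), and this assay moves by a 1.3-fold higher number from compound 1 to compound 2 (0.13 log units; within the scatter), so the two compounds cannot be told apart. Compound 3 is compound 1 with a change in its core, (6-methoxypyridin-3-yl in place of 3-methoxyphenyl on a nitrogen on an aromatic ring), and here the step is a 1.4-fold higher number from compound 1 to compound 3 (0.16 log units; within the scatter), again within the scatter. The three measured compounds therefore all sit at much the same weak level, and no order among them can be claimed.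

Compound 4 `COc1ccc(Nc2nc(Oc3cccc(NC(=O)/C=C/C(C)C)c3)c3sccc3n2)cn1` is compound 3 carrying the change (3-methylbut-1-en-1-yl in place of 2-methylprop-1-en-1-yl on a carbonyl carbon), the same change already seen from compound 1 to compound 2, at a place described in the same words. Compound 4 is expected to move from compound 3 by about a 1.3-fold higher number from compound 3 to compound 4 (0.11 log units; within the scatter), because the earlier instance gave a 1.3-fold higher number from compound 1 to compound 2 (0.13 log units; within the scatter), and the different core of compound 3 is not expected to alter that. Compound 4 is thus estimated at 52000 nM in this assay, most likely between 26000 nM and 100000 nM.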

Compound 4, half-maximal inhibitory concentration: > 50000 nM
Compound 4: no number, only a limit (the forecaster's own chance of this, stated with the estimate: 10%); the middle value does not contradict the limit.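

In this assay compound 4 gives a limit and not a number, > 50000 nM. Carrying 3-methylbut-1-en-1-yl in place of 2-methylprop-1-en-1-yl onto the core of compound 3 gives an at least 1.2-fold higher number from compound 3 to compound 4 (0.09 log units; that floor lies within the scatter), so this series offers no sign that the change acts differently on the second core, but also no proof that it acts alike: the same change on two cores in this assay, a 1.3-fold higher number (0.13 log units; within the scatter) from compound 1 to compound 2 and an at least 1.2-fold higher number (0.09 log units; that floor lies within the scatter) from compound 3 to compound 4; the limit leaves it open whether they differ

The companion change, 6-methoxypyridin-3-yl in place of 3-methoxyphenyl, gives an at least 1.3-fold higher number from compound 2 to compound 4 (0.12 log units; that floor lies within the scatter) when read with the 3-methylbut-1-en-1-yl group in place, and it too cannot be matched exactly with its earlier instance: the same change on two cores in this assay, a 1.4-fold higher number (0.16 log units; within the scatter) from compound 1 to compound 3 and an at least 1.3-fold higher number (0.12 log units; that floor lies within the scatter) from compound 2 to compound 4; the limit leaves it open whether they differ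

The compounds shown leave open whether a chain of another kind on the carbonyl carbon, such as a straight saturated alkyl chain or a chain carrying an amine, would give a clearly lower number in this assay. Also open, as far as these compounds go, is whether a fluorine or a carboxylic acid in place of the methoxy group would move the number beyond the scatter.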